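A few compounds are considered here, and "the series" means these few. Any claim that something is new, unique, unknown or untested is made for them only; others in the source may bear on it.

Compound 1 `CN(C)CCCNc1nc2cc([N+](=O)[O-])ccc2nc1NCc1ccc(Br)cc1`, compound 2 `COc1ccc(CNc2nc3ccc([N+](=O)[O-])cc3nc2NCCCN(C)C)cc1` and compound 3 `CN(C)CCCNc1nc2cc([N+](=O)[O-])ccc2nc1NCc1ccc(Cl)c(C(F)(F)F)c1` differ in the aromatic group on a saturated chain carbon bound to a nitrogen on an aromatic ring. In an ADME assay on HEK293 cells (Homo sapiens) for cytotoxicity, read by MTT assay, with a stated time of 24 h (on this read-out higher numbers stand for weaker inhibition and lower numbers for stronger inhibition), compound 1 gives 9.63 ug/mL, compound 2 gives 38.6 ug/mL and compound 3 gives 3.26 ug/mL. Compound 3 therefore has the lowest number of the three, which here means the strongest inhibition.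

Compound 4 `CN(C)CCCNc1nc2cc([N+](=O)[O-])ccc2nc1NCc1cc(F)cc(C(F)(F)F)c1`, not yet measured, carries 3-fluoro-5-(trifluoromethyl)phenyl in place of the 4-chloro-3-(trifluoromethyl)phenyl of compound 3: 3-fluoro-5-(trifluoromethyl)phenyl in place of 4-chloro-3-(trifluoromethyl)phenyl on a saturated chain carbon bound to a nitrogen on an aromatic ring.

All three measured steps change this same aromatic group. The closest guide is a 3.0-fold lower number from compound 1 to compound 3 (0.47 log units; beyond the scatter), a modest step that brought in the group now being replaced. The largest is a 12-fold lower number from compound 2 to compound 3 (1.07 log units; beyond the scatter), and it starts from the 4-methoxyphenyl group, which resembles the new group less. The remaining step, a 4.0-fold higher number from compound 1 to compound 2 (0.60 log units; beyond the scatter), is also modest. Among the measured compounds shown here, no measured compound carries the new group, so none of these steps tests it directly.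

The trifluoromethyl group stays, and one halogen takes the place of another, so no step beyond the scatter is expected in this assay. The estimated step, leaning slightly upward, is a 1.4-fold higher number from compound 3 to compound 4 (0.14 log units; within the scatter). For compound 4 the estimate is 4.5 ug/mL, with an expected range of 1.9 ug/mL to 11 ug/mL.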

Compound 4, half-maximal inhibitory concentration: 2.67 ug/mL
The estimate for compound 4 lay 1.7-fold (0.23 log units) above the measured number; the range from low to high includes it.
By their numbers in this assay, from the lowest: compounds 4 and 3 (each within the scatter of the next); then compound 1; then compound 2.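

In this assay, 3-fluoro-5-(trifluoromethyl)phenyl in place of 4-chloro-3-(trifluoromethyl)phenyl gives a 1.2-fold lower number from compound 3 to compound 4 (0.09 log units; within the scatter), so at this position neither the exchange of chlorine for fluorine nor the different placing of the groups on the ring gives a readable change. The new group also keeps the distance from the other two aromatic groups, with a 3.6-fold lower number from compound 1 to compound 4 (0.56 log units; beyond the scatter) and a 14-fold lower number from compound 2 to compound 4 (1.16 log units; beyond the scatter), so among the four compounds shown, the two with a trifluoromethyl-bearing ring both have lower numbers than those with 4-bromophenyl and 4-methoxyphenyl, and none goes against this. No measurement shown here offers an explanation for these numbers.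

Going by these compounds, whether the trifluoromethyl group itself goes with the lower numbers remains open, as that would take a comparison with the same ring carrying a nitrile or a plain hydrogen in its place. Also open, on these data alone, is how the number responds to changes elsewhere, such as a longer chain in place of the dimethylaminopropyl chain or a morpholine in place of its dimethylamine.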